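Pentylamino in place of methyl on the shared core

The compounds below may be only part of what the source reports. "The series", "measured", "known", "first", "only" and "open" are said of these compounds alone.

Compound 1 `C=CCOc1ccc(C(=O)Nc2cccc(C)n2)cc1` gives 6000 nM in an in vitro assay on HEK-tsA201 cells for antagonist activity at Neuronal acetylcholine receptor; alpha4/beta2 (Homo sapiens), read by fluorescence and calcium flux; on this read-out lower numbers stand for stronger inhibition and higher numbers for weaker inhibition.
Compound 2 `CCCOc1ccc(C(=O)Nc2cccc(C)n2)cc1` gives 7500 nM in this assay.

Compound 2 has the highest of the two numbers, and its nearest neighbour is compound 1: a 1.3-fold higher number from compound 1 to compound 2 (0.10 log units; within the scatter), so the two cannot be told apart. Compound 3 `CCCCCNc1cccc(NC(=O)c2ccc(OCCC)cc2)n1` keeps the propoxy chain of compound 2 and differs elsewhere: pentylamino in place of methyl on an aromatic carbon. Going by the values given here, the only measured step, a 1.3-fold higher number from compound 1 to compound 2 (0.10 log units; within the scatter), changed the chain on the ring oxygen, not this aromatic carbon, so no measured step bears on the new change, and there is nothing to show whether a large group entering here helps or hurts. The estimate therefore stays near compound 2 with a wide range: compound 3 is expected to give 7000 nM, between 1500 nM and 30000 nM. This estimate means a step of a 1.1-fold lower number from compound 2 to compound 3 (0.03 log units; within the scatter), which is expected to lie within the scatter.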

Compound 3, half-maximal inhibitory concentration: > 100000 nM
Compound 3: only a limit was reported; the forecaster's own chance of this, stated with the estimate: 20%; at least 14-fold (1.15 log units) between middle value and limit.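

Replacing methyl with pentylamino on this aromatic carbon, next to the ring nitrogen, has a clear effect on inhibition, which the earlier change on the chain at the ring oxygen did not show: the result is an at least 13-fold higher number from compound 2 to compound 3 (1.12 log units; beyond the scatter). The result for compound 3 is a limit of the assay, not a number: the limit of > 100000 nM in this assay, at which 1 of the 3 values shown sits. So this position does not accept every replacement for methyl, and pentylamino here goes with much weaker inhibition.

This single step cannot separate the effect of the nitrogen joined to the ring from that of the chain it carries, and a plain amine or a pentyl chain on the same carbon would tell the two apart. It also leaves open whether a short group such as methylamino would keep the inhibition seen with methyl.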